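The compounds below may be only part of what the source reports. "The series", "measured", "known", "first", "only" and "open" are said of these compounds alone.

Measured compounds in the series:
- compound 1 `CCC(C)(C)Cc1c[nH]c(CCc2ccc(-c3ccncc3)cc2)n1`: 103 nM
- compound 2 `CCC(C)(C)Cc1c[nH]c(CCc2ccc(-c3cccnc3)cc2)n1`: 97 nM
- compound 3 `CCC(C)(C)Cc1c[nH]c(CCc2ccc(N3CCCCC3)cc2)n1`: 133 nM

In a functional assay on HEK293 cells for agonist activity at Bombesin receptor subtype-3 (Mus musculus), read by luminescence and calcium flux, with a stated time of 10 min (a higher number here means that more compound is needed for the effect, a lower number that less compound is needed), compound 2 gives 97 nM, the lowest of the three numbers, though this says little: the gaps to its neighbours, a 1.1-fold lower number from compound 1 to compound 2 (0.03 log units; within the scatter) and a 1.4-fold higher number from compound 2 to compound 3 (0.14 log units; within the scatter), are both within the scatter, as is a 1.3-fold higher number from compound 1 to compound 3 (0.11 log units; within the scatter). On these numbers the three compounds are not distinguishable.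

Compound 4 `CCC(C)(C)Cc1c[nH]c(CCc2ccc(-c3ccc(F)cn3)cc2)n1` is the next variant at the same position. Its difference from compound 2 is 5-fluoropyridin-2-yl in place of pyridin-3-yl on an aromatic carbon. The three measured steps all bear on this change, since each swaps the group on that aromatic carbon, para to a large group, and every one of them stays within the scatter. A second six-membered aromatic ring with one nitrogen, now carrying a fluorine, is therefore expected to leave this assay essentially unchanged, and the step of a 1.1-fold higher number from compound 2 to compound 4 (0.05 log units; within the scatter) is expected to be no larger than the scatter. For compound 4 the estimate in this assay is 110 nM, with a range from 50 nM to 250 nM.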

Compound 4, half-maximal effective concentration: 105 nM
Beside the measured number, compound 4's estimate is 1.0-fold (0.02 log units) above it, and the stated range covers the measured number.
By their numbers in this assay, from the lowest: compounds 2, 1, 4 and 3 (each within the scatter of the next).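

In this assay, a ring carrying a fluorine fits the flat picture at this aromatic carbon: a 1.1-fold higher number from compound 2 to compound 4 (0.03 log units; within the scatter), a 1.0-fold higher number from compound 1 to compound 4 (0.01 log units; within the scatter) and a 1.3-fold lower number from compound 3 to compound 4 (0.10 log units; within the scatter). The earlier compounds shown here covered only unsubstituted pyridinyl groups and piperidin-1-yl, so compound 4 extends the range of groups that stay within the scatter to a substituted aromatic ring, with 5-fluoropyridin-2-yl giving no separation from any of them. Nothing at hand accounts for this flat response.

As far as these compounds go, it remains open whether any group at this place gives a step beyond the scatter, for example a carboxylic acid, a primary amine or a longer alkyl chain. The parts played by the fluorine and by the ring's point of attachment also stay unseparated, and plain pyridin-2-yl would address that.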